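From Phenyl to Imidazole in a Cell Activation Series

The source may report more compounds than this note shows. Statements on the series, on what has been measured and on what is new or still open speak of the compounds shown alone.

In a functional assay on A-375 cells (Homo sapiens) for activation, with a stated time of 3 days (a higher number here means that more compound is needed for the effect, a lower number that less compound is needed), compound 1 `O=C(Nc1ccc(-c2cscn2)cc1)[C@H]1CCCN(Cc2ccc(F)c(F)c2)C1` gives 270 nM and compound 2 `O=C(Nc1ccc(-c2cscn2)cc1)C1CCCN(Cc2ccc(Cl)c(Cl)c2)C1` gives 3000 nM as its value. Compound 3 `O=C(Nc1ccc(-c2ccccc2)cc1)C1CCCN(Cc2ccc(F)c(F)c2)C1` gives 5000 nM as its value, within the scatter of compound 2 and clearly above compound 1. Compound 4 `O=C(Nc1ccc(-c2ncc[nH]2)cc1)C1CCCN(Cc2ccc(F)c(F)c2)C1` has 1H-imidazol-2-yl in place of the phenyl of compound 3 on an aromatic carbon 1H-imidazol-2-yl in place of phenyl on an aromatic carbon and is still unmeasured. Among the measured compounds shown here, no measured pair shows this change alone. Compound 1 also lacks that phenyl and gives 270 nM despite other differences, while compound 2 lacks it too yet stays within the scatter of compound 3. A moderate fall is therefore expected, with a 3.3-fold lower number from compound 3 to compound 4 (0.52 log units; beyond the scatter) as the estimated step. Compound 4 is estimated at 1500 nM with a range of 300 nM to 7000 nM expected.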

Compound 4, half-maximal effective concentration: 8000 nM
Beside the measured number, compound 4's estimate is 5.3-fold (0.73 log units) below it; the measured number lies above the stated range.
By their numbers in this assay, from the lowest: compound 1; then compounds 2, 3 and 4 (each within the scatter of the next, the first and the last beyond it).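

Among the compounds shown here, at this position, para to a large group, 1H-imidazol-2-yl in place of phenyl gives the first step that changes one place alone: a 1.6-fold higher number from compound 3 to compound 4 (0.20 log units; within the scatter) in this assay. The five-membered aromatic ring, with its hydrogen-bond donor and acceptor, therefore leaves the number within the scatter of the six-membered carbon ring. Nothing measured here offers a reason for this result.

As far as these compounds go, whether an amine or a carboxylic acid on this aromatic carbon would shift the number remains open. A single pair also cannot tell whether this swap would behave the same way in compounds that differ elsewhere.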